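Working notes: the step from compound 3 to compound 4

The source may hold more compounds than are shown below. What is called first, only, known or untested is meant among the compounds shown, and "the series" means these compounds.

The shared core carries a ring amine whose substituent varies across the set. Compound 1 `CC(C)(C)OC(=O)N1CCC(Oc2cccc3c2CCN3c2ccc(S(C)(=O)=O)cc2)CC1` gives 158 nM in a functional assay on CHO-K1 cells for agonist activity at Glucose-dependent insulinotropic receptor (Homo sapiens), read by a luciferase reporter, with a stated time of 5 h; on this read-out higher numbers stand for an effect only at larger amounts of compound and lower numbers for an effect already at smaller amounts. Compound 2 `CC(C)COC(=O)N1CCC(Oc2ncnc3c2CCN3c2ccc(S(C)(=O)=O)cc2F)CC1` gives 25.1 nM in this assay. Compound 3 `CSC(=O)N1CCC(Oc2ncnc3c2CCN3c2ccc(S(C)(=O)=O)cc2F)CC1` gives 251 nM in this assay; among the three measured numbers it stands highest, with compound 1 nearest and within the scatter, and compound 2 furthest, beyond the scatter. Among the measured compounds shown here, the one single-point step in the set is a 10-fold higher number from compound 2 to compound 3 (1.00 log units; beyond the scatter), which shows that the group on the amine nitrogen in a ring can move the read-out by a modest amount.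

Compound 4 `CS(=O)(=O)c1ccc(N2CCc3c(OC4CCN(C5=NCCCN5)CC4)ncnc32)c(F)c1` has not yet been measured. It differs from compound 3 by a group of 6 heavy atoms (4 carbon, 2 nitrogen; one six-membered non-aromatic ring with 2 hetero atoms) in place of a group of 4 heavy atoms (2 carbon, 1 oxygen, 1 sulfur; no ring), on an amine nitrogen in a ring. For the measured compounds named here, no measured step covers a ring-bearing group entering at this position, so the direction of the change cannot be read from the set; the step from compound 2 to compound 3 only marks the position as one where the number responds to what sits there. For compound 4 the value in this assay is therefore expected near that of compound 3, with a wide range to either side, estimated as 120 nM (from 15 nM to 1000 nM), which corresponds to an expected step of a 2.1-fold lower number from compound 3 to compound 4 (0.32 log units; beyond the scatter).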

Compound 4, half-maximal effective concentration: 2000 nM
The estimate for compound 4 lay 17-fold (1.22 log units) below the measured number, and the stated range ends below it.
By their numbers in this assay, from the lowest: compound 2; then compounds 1 and 3 (each within the scatter of the next); then compound 4.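

In this assay, among the compounds shown here, the first ring-bearing group on this amine nitrogen in a ring gives an 8.0-fold higher number from compound 3 to compound 4 (0.90 log units; beyond the scatter) and an 80-fold higher number from compound 2 to compound 4 (1.90 log units; beyond the scatter), both beyond the scatter. The earlier compounds shown here marked the position only as responsive; these steps show that replacing either carbonyl-bearing group with this six-membered non-aromatic ring with 2 hetero atoms moves the number upward, towards an effect only at larger amounts of compound, and that the move is larger from the isobutoxy-bearing compound 2. The change removes the carbonyl and adds a ring and 1 hydrogen-bond donor together, and no measurement at hand bears on the reason for the rise.

The compounds shown do not separate these features: a non-ring group such as an acyclic guanidine, or a ring lacking the donor such as a phenyl ring, would be needed to tell them apart on this nitrogen. As far as these compounds go, it also remains open how an acetyl group or a longer alkoxy chain on the carbonyl carbon would compare, and whether the same replacement would give a step of similar size on the core of compound 1.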